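This account rests on a few compounds, and the source may have more. Where it says the series, first, only, none or still open, it means among the compounds named here.

In a physicochemical assay for solubility, in phosphate buffer, measured as kinetic solubility, with a stated time of 1 h, at pH 7.4 (a higher number here means a more soluble compound, a lower number a less soluble compound), compound 1 `CC(C)(c1cc([C@@]23CCOC[C@@H]2C3)nc(-c2cccc(O)c2)n1)S(C)(=O)=O` gives 148 ug/mL, compound 2 `CCNC(=O)Nc1ccc(-c2nccc([C@]34CCOC[C@H]3C4)n2)cc1` gives 125 ug/mL and compound 3 `CC(C)(c1cc([C@@]23CCOC[C@@H]2C3)nc(-c2ccc(NC(=S)NCCO)cc2)n1)S(C)(=O)=O` gives 145 ug/mL. Compound 3 therefore stands within the scatter of both other compounds, and the three numbers give no ranking. Compound 4 `CCNC(=O)Nc1ccc(-c2nc(C(C)(C)S(C)(=O)=O)cc([C@@]34CCOC[C@@H]3C4)n2)cc1` differs from compound 3 in one place, on a nitrogen on an aromatic ring: a group of 5 heavy atoms (3 carbon, 1 nitrogen, 1 oxygen; no ring) in place of a group of 6 heavy atoms (3 carbon, 1 nitrogen, 1 oxygen, 1 sulfur; no ring), on a nitrogen on an aromatic ring, with ethylcarbamoyl entering. For the measured compounds named here, no pair of measured compounds sizes this change directly. Compound 2 also carries ethylcarbamoyl and gives 125 ug/mL, so no step beyond the scatter is expected. The expected change is a 1.2-fold lower number from compound 3 to compound 4 (0.08 log units; within the scatter), slightly downward and within the scatter. Compound 4 is estimated at 120 ug/mL, with an expected range of 65 ug/mL to 175 ug/mL.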

Compound 4, solubility: 78 ug/mL
Compound 4: the middle estimate sits 1.5-fold (0.19 log units) above what was measured; measured number inside the range.
By their numbers in this assay, from the lowest: compounds 4, 2, 3 and 1 (each within the scatter of the next).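

In this assay, the swap on a nitrogen on an aromatic ring, with ethylcarbamoyl entering for the group of 6 heavy atoms, is now sized directly as a 1.9-fold lower number from compound 3 to compound 4 (0.27 log units; within the scatter) in this series. For the compounds shown here, this is the first direct reading of this change, and it shows no difference beyond the scatter at this position. No measured property bears on this result.

On these data alone, it remains open whether a longer chain, an amine or a carboxylic acid on this nitrogen would give a step beyond the scatter.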